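Hydroxymethyl in place of hydrogen: clearance of compound 4

The compounds below may be only part of what the source reports. "The series", "measured", "known", "first", "only" and "open" are said of these compounds alone.

Measured so far in an ADME assay on the whole organism (Rattus norvegicus, strain Sprague-Dawley) for pharmacokinetics, read by LC-MS, using cassette dosing, at a dose of 0.1 mg/kg by the intravenous route; a higher number here means faster removal of the compound, a lower number slower removal
- compound 1 `CC(C)[C@@H]1NC(=O)[C@H](Cc2ccc(F)cc2)NC(=O)[C@H](Cc2ccc(Cl)cc2)NC(=O)CCCSC[C@@H](C(=O)N2CCC[C@H]2C(=O)NCCCCNC(=N)N)NC(=O)[C@H](CC(N)=O)NC1=O` gives 7.5 mL/min/kg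
- compound 2 `CC(C)[C@@H]1NC(=O)[C@H](Cc2cccs2)NC(=O)[C@H](Cc2ccc(O)cc2)NC(=O)CCCSC[C@@H](C(=O)N2CCC[C@H]2C(=O)NCCCCN)NC(=O)[C@H](CC(N)=O)NC1=O` gives 7.2 mL/min/kg
- compound 3 `CC(C)[C@@H]1NC(=O)[C@H](Cc2ccc(F)cc2)NC(=O)[C@H](Cc2ccc(Cl)cc2)NC(=O)CCCSC[C@@H](C(=O)N2CSC[C@H]2C(=O)NCCCCNC(=N)N)NC(=O)[C@H](CC(N)=O)NC1=O` gives 9.9 mL/min/kg

The three values lie within the scatter of one another, so compound 1 cannot be separated from either neighbour on these numbers. Next in line for this assay is compound 4 `CC(C)[C@@H]1NC(=O)[C@H](Cc2ccc(F)cc2)NC(=O)[C@H](Cc2ccc(Cl)cc2)NC(=O)CCCSC[C@@H](C(=O)N2CCC[C@H]2C(=O)N[C@@H](CO)CCCNC(=N)N)NC(=O)[C@H](CC(N)=O)NC1=O` which carries one change from compound 1 (hydroxymethyl in place of hydrogen on a saturated chain carbon bound to an amide-type nitrogen and a saturated chain carbon): hydroxymethyl in place of hydrogen on a saturated chain carbon bound to an amide-type nitrogen and a saturated chain carbon. Within the data shown here, no measured pair in this set differs in one place, so no direct step informs the change. Even with its altered structure, compound 3 at 9.9 mL/min/kg stays within the scatter of compound 1 at 7.5 mL/min/kg and this sets a modest expectation. The estimated step of a 1.1-fold higher number from compound 1 to compound 4 (0.03 log units; within the scatter) is expected to go no further than the scatter, with no firm direction. Compound 4 is estimated at 8 mL/min/kg with an expected range of 4 mL/min/kg to 16 mL/min/kg pending measurement.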

Compound 4, clearance: 3.8 mL/min/kg
For compound 4 the middle estimate is 2.1-fold (0.32 log units) above the measured one; the whole stated range lies above it.
By their numbers in this assay, from the lowest: compounds 4, 2, 1 and 3 (each within the scatter of the next, the first and the last beyond it).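

In this assay the series now has its first pair differing in one place, and the step is a 2.0-fold lower number from compound 1 to compound 4 (0.30 log units; within the scatter). On this single pair, hydroxymethyl in place of hydrogen on a saturated chain carbon bound to an amide-type nitrogen and a saturated chain carbon cannot be separated from the scatter, so neither a gain nor a loss can be claimed for this change. Nothing available here bears on what lies behind this result.

From the compounds shown here alone, whether a methyl group, a hydroxyethyl chain or a carboxylic acid on the same carbon would give a step beyond the scatter remains open. Also open, going by these compounds, is whether hydroxymethyl would give a similar step on the core of compound 3, or with the opposite configuration at this carbon.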